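Six-atom sulfur group replaced by trifluoromethyl on the amide ring

This account rests on a few compounds, and the source may have more. Where it says the series, first, only, none or still open, it means among the compounds named here.

Measured in a functional assay on DU-145 cells (Homo sapiens) for antiproliferative activity, read by propidium iodide staining, with a stated time of 96 h; on this read-out higher numbers stand for weaker inhibition and lower numbers for stronger inhibition:
- compound 1 `CC(O)(COc1ccc(S(F)(F)(F)(F)F)cc1)C(=O)Nc1ccc(S(F)(F)(F)(F)F)cc1` gives 24900 nM
- compound 2 `CC(O)(COc1cccc(S(F)(F)(F)(F)F)c1)C(=O)Nc1cccc(S(F)(F)(F)(F)F)c1` gives 30700 nM
- compound 3 `CC(O)(COc1cccc(C(F)(F)F)c1)C(=O)Nc1cccc(S(F)(F)(F)(F)F)c1` gives 31700 nM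

Compound 1 and compound 2 are built from the same atoms joined differently; the difference between the two cores is not broken down here. Their two values sit within the scatter of each other, so nothing separates them.

Compound 3 differs from compound 2 by a group of 4 heavy atoms (1 carbon, 3 fluorine; no ring) in place of a group of 6 heavy atoms (5 fluorine, 1 sulfur; no ring), on an aromatic carbon. This gave a 1.0-fold higher number from compound 2 to compound 3 (0.01 log units; within the scatter), a step that is flat.

Compound 4 `CC(O)(COc1ccc(S(F)(F)(F)(F)F)cc1)C(=O)Nc1ccc(C(F)(F)F)cc1` has not been measured. It differs from compound 1 by a group of 4 heavy atoms (1 carbon, 3 fluorine; no ring) in place of a group of 6 heavy atoms (5 fluorine, 1 sulfur; no ring), on an aromatic carbon. The place is not the same as in the earlier pair: there the entering group sat meta to a large group, here it sits para to a large group, so this is the same kind of change rather than the same change.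

Given that, the step from compound 1 to compound 4 is expected to be a 1.0-fold higher number from compound 1 to compound 4 (0.02 log units; within the scatter), resting on the flat result a 1.0-fold higher number from compound 2 to compound 3 (0.01 log units; within the scatter). Compound 4 is therefore estimated at 26000 nM in this assay , with a range from 13000 nM to 52000 nM.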

Compound 4, half-maximal inhibitory concentration: 27400 nM
Beside the measured number, compound 4's estimate is 1.1-fold (0.02 log units) below it; low and high end bracket the measured number.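

In this assay, trifluoromethyl entering on the amide ring in place of the six-atom sulfur group gives a 1.1-fold higher number from compound 1 to compound 4 (0.04 log units; within the scatter), a flat step. Set beside the earlier step, the swap reads the same on both cores: the same change on two cores in this assay, a 1.0-fold higher number (0.01 log units; within the scatter) from compound 2 to compound 3 and a 1.1-fold higher number (0.04 log units; within the scatter) from compound 1 to compound 4, 1.1-fold (0.03 log units) apart, within the scatter of two such steps. This shows that the change was tolerated on these two cores, but the earlier step sits on the other ring and in a different place, so the match is between two like changes rather than a repeat of one, and two flat steps do not establish a rule for the series.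

The compounds shown leave open whether the swap would stay flat with trifluoromethyl on both rings at once, or on a core giving much lower numbers. They also leave open whether a different group on either ring, such as a nitrile, an amine or a carboxylic acid, would move the number at all.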